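The source may report more compounds than this note shows. Statements on the series, on what has been measured and on what is new or still open speak of the compounds shown alone.

Compound 1 `COc1cc(-c2cc(/C=C/C(=O)c3ccc(Cl)c(Cl)c3)[nH]n2)cc(OC)c1OC`: -10%
Compound 2 `COc1ccc(C(=O)/C=C/c2cc(-c3cc(OC)c(OC)c(OC)c3)n[nH]2)cc1OC`: -84%
Compound 3 `COc1cc(-c2cc(/C=C/C(=O)c3ccc(F)c(F)c3)[nH]n2)cc(OC)c1OC`: -47%

In a functional assay on 786-0 cells (Homo sapiens) for cytotoxicity, read by sulforhodamine B assay, with a stated time of 48 h, tested at 100 uM (a lower number here means a stronger effect, a higher number a weaker effect of the compound at the concentration tested), compound 2 gives -84%, the lowest of the three numbers; its nearest neighbour is compound 3, and the step of a number 37 percentage points higher from compound 2 to compound 3 (beyond the scatter) is beyond the scatter, while the gap to compound 1, seen as a number 74 percentage points lower from compound 1 to compound 2 (beyond the scatter), is larger still. Compound 4 `COc1cc(C(=O)/C=C/c2cc(-c3cc(OC)c(OC)c(OC)c3)n[nH]2)cc(OC)c1OC` has not yet been measured. It differs from compound 2 by methoxy in place of hydrogen on an aromatic carbon, the new group sitting on an aromatic carbon of a six-membered aromatic ring of carbon only, ortho to a methoxy group and meta to another. The measured steps that touch this part of the molecule, a number 74 percentage points lower from compound 1 to compound 2 (beyond the scatter) and a number 37 percentage points higher from compound 2 to compound 3 (beyond the scatter), both swap the whole phenyl group on the carbonyl carbon, and both were large; none of them adds a single methoxy to a ring already bearing two. The step of a number 4 percentage points higher from compound 2 to compound 4 (within the scatter) is therefore expected to stay within the scatter, in either direction. Compound 4 is estimated at -80%, between -100% and -50%.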

Compound 4, a percentage reported as activity, at one concentration (the size of the read-out at that concentration, not a potency): -98%
For compound 4 the middle estimate is 18 percentage points above the measured one, and the stated range covers the measured number.
By their numbers in this assay, from the lowest: compound 4; then compound 2; then compound 3; then compound 1.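

In this assay, for the compounds shown here, methoxy in place of hydrogen on an aromatic carbon, ortho to a methoxy group, gives a number 14 percentage points lower from compound 2 to compound 4 (beyond the scatter), so a single added group at this position moves the read-out beyond the scatter, whereas the earlier steps all exchanged the whole phenyl group on the carbonyl carbon. Across compound 1, compound 2 and compound 4 the number falls as methoxy groups on this ring increase, but compound 3, with none, still lies well below compound 1. No available evidence accounts for this step.

What the compounds shown leave open is whether the effect belongs to methoxy itself or would also appear with a hydroxyl, an amine or a longer alkoxy chain at this position. They also leave open whether a methoxy added to the ring of compound 3 would shift its number in the same direction.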